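A Smaller Tail Group on a Scaffold Without Effect

The compounds below may be only part of what the source reports. "The series", "measured", "known", "first", "only" and "open" are said of these compounds alone.

compound 1 `C/N=C(/NC#N)NCCCCCn1nc(-c2ccccc2)c(C)cc1=O` — > 100 mg/kg
compound 2 `C/N=C(/NC#N)NCCCCCCn1nc(-c2ccccc2)ccc1=O` — > 100 mg/kg

In a functional assay on the whole organism (stomach) with Rattus norvegicus as the target (a higher number here means that more compound is needed for the effect, a lower number that less compound is needed), compound 1 reaches only the assay limit, > 100 mg/kg, so no number is known. Compound 2 likewise gives only a limit, > 100 mg/kg. Both sit at the limit of > 100 mg/kg in this assay, at which 2 of the 2 values shown sit. Going by the values given here, because no step between measured compounds exists, the two values show only that neither reaches an effect. Compound 3 `C/N=C(\S)NCCCCCn1nc(-c2ccccc2)ccc1=O` differs from compound 2 by a group of 5 heavy atoms (2 carbon, 2 nitrogen, 1 sulfur; no ring) in place of a group of 8 heavy atoms (4 carbon, 4 nitrogen; no ring), on a saturated chain carbon, five bonds along the chain from an aromatic nitrogen. Given that compound 2 stands at a limit, no shift beyond the scatter is expected. Compound 3 is estimated at 150 mg/kg, between 40 mg/kg and 600 mg/kg. That expectation means a step that the limit leaves unreadable from compound 2 to compound 3.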

Compound 3, dose for half-maximal effect: 35.3 mg/kg
For compound 3 the middle estimate is 4.2-fold (0.63 log units) above the measured one, outside the stated range (below it).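

In this assay, going by these compounds alone, this position proves able to respond: the change on the saturated chain carbon gives an at least 2.8-fold lower number from compound 2 to compound 3 (0.45 log units; beyond the scatter) and yields the first actual number in the set. The step is only a minimum, as compound 2 gives a limit and not a number. Compound 3 alone escapes that limit: the limit of > 100 mg/kg in this assay, at which 2 of the 3 values shown sit.

Whether the sulfur or the smaller group accounts for the step remains open. A matching group with oxygen in place of sulfur, or a simple amine at this position, would help separate the two.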